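Adding a Phenyl Group to Compound 1

The source may report more compounds than this note shows. Statements on the series, on what has been measured and on what is new or still open speak of the compounds shown alone.

Among the measured compounds shown here, in a functional assay on A2780 cells (Homo sapiens) for cytotoxicity, read by MTT assay, with a stated time of 72 h (on this read-out lower numbers stand for stronger inhibition and higher numbers for weaker inhibition), compound 1 (`Cc1cc(C)cc(C(=O)N(CCCCCC(=O)Nc2ccccc2N)CC(=O)NCc2ccccc2)c1`) gives 20900 nM, the higher of the only two numbers available so far. Its closest and only comparator, compound 2 (`Cc1ccc(CNC(=O)CN(CCCCCC(=O)Nc2ccccc2N)C(=O)c2cc(C)cc(C)c2)cc1`), gives 9800 nM. Compound 3 (`Cc1cc(C)cc(C(=O)N(CCCCCC(=O)Nc2cc(-c3ccccc3)ccc2N)CC(=O)NCc2ccccc2)c1`) has not yet been measured. It departs from compound 1 as follows: phenyl in place of hydrogen on an aromatic carbon. This is phenyl in place of hydrogen on an aromatic carbon, para to an amino group and meta to a large group.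

For the measured compounds named here, only one measured step bears on this change, and only loosely: a 2.1-fold lower number from compound 1 to compound 2 (0.33 log units; beyond the scatter). That step, methyl in place of hydrogen on an aromatic carbon, is modest but beyond the scatter, and it lies elsewhere in the molecule. Going by the values given here, no measured compound carries a phenyl group at the new place, so the direction is tentative, and a lower number in this assay is expected, with wide uncertainty. The step expected is a 3.0-fold lower number from compound 1 to compound 3 (0.48 log units; beyond the scatter). Compound 3 is therefore estimated at 7000 nM, with an expected range of 1500 nM to 25000 nM.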

Compound 3, half-maximal inhibitory concentration: 17100 nM
Estimate against measurement, compound 3: 2.4-fold (0.39 log units) below; the range from low to high includes it.
By their numbers in this assay, from the lowest: compounds 2, 3 and 1 (each within the scatter of the next, the first and the last beyond it).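

Phenyl on this aromatic carbon, para to an amino group and meta to a large group, gives in this assay a 1.2-fold lower number from compound 1 to compound 3 (0.09 log units; within the scatter) and this assay therefore does not separate the two compounds. The earlier step concerned only a methyl group elsewhere in the molecule, whereas this result shows that the aromatic carbon in question can carry a whole six-membered aromatic ring of 6 heavy atoms with no change in the number that exceeds the scatter of repeated measurements. No independent measurement is available that could account for this result.

The compounds shown leave open whether a smaller or different substituent at this same place, such as a methyl group, a methoxy group or an amine, would also leave the number unchanged, or whether a carboxylic acid on the added phenyl ring would shift it. They also leave open how the phenyl group at this place would behave together with the methyl group that sets compound 2 apart from compound 1.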